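From compound 2 to compound 4: a ring swap at the amide

This account rests on a few compounds, and the source may have more. Where it says the series, first, only, none or still open, it means among the compounds named here.

Compound 1 `CC(C)C(=O)N1CCc2cc(CNC(=O)c3ccc(Cl)cc3)ccc21`: 92%
Compound 2 `CCC(=O)N1CCc2cc(CNC(=O)c3cccc(F)c3)ccc21`: 82%
Compound 3 `CCC(=O)NCc1ccc2c(c1)CCN2C(=O)c1ccccc1`: 41%

These three compounds have been measured in an assay on HEK293 cells for inhibition of Indoleamine 2,3-dioxygenase 1 (Homo sapiens), tested at 10 uM; a lower number here means less inhibition, a higher number more inhibition at the concentration tested (going by the name of the read-out). Compound 2 holds the second highest of the three numbers; its nearest neighbour is compound 1, whose value lies higher by an amount within the usual scatter, and its furthest is compound 3, whose value lies well below, beyond the scatter. Compound 4 `CCC(=O)N1CCc2cc(CNC(=O)c3cccs3)ccc21` differs from compound 2 in one place: thiophen-2-yl in place of 3-fluorophenyl on a carbonyl carbon. Within the data shown here, no step between measured compounds that differ in a single place is available, so the size of this change cannot be read from the data. In this assay a small drop or none beyond the scatter is expected. Compound 4 is expected to give 75%, with a range from 50% to 92%. The expected step is a number 7 percentage points lower from compound 2 to compound 4 (within the scatter).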

Compound 4, a percentage reported as inhibition, at one concentration (the size of the read-out at that concentration, not a potency): 89%
Compound 4: the middle estimate sits 14 percentage points below what was measured, within the range that was stated.
By their numbers in this assay, from the lowest: compound 3; then compounds 2, 4 and 1 (each within the scatter of the next).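

In this assay, among these compounds, thiophen-2-yl in place of 3-fluorophenyl on a carbonyl carbon gives a number 7 percentage points higher from compound 2 to compound 4 (within the scatter), the first comparison here of compounds that differ in one place. At this position, then, a five-membered aromatic ring with one hetero atom serves as well as a six-membered carbon ring, within the scatter of the assay. Nothing measured here accounts for this result. On these data alone, whether a non-aromatic group such as cyclohexyl, or a thiophene ring carrying an amine or a carboxylic acid, would keep the inhibition remains open.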